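The source may hold more compounds than are shown below. What is called first, only, known or untested is meant among the compounds shown, and "the series" means these compounds.

Measured so far:
Compound 1, `COc1ccc(C(=O)C#Cc2cn(COCCO)c(=O)[nH]c2=O)cc1` — in a functional assay on L1210 cells (Mus musculus) for cytotoxicity (on this read-out lower numbers stand for stronger inhibition and higher numbers for weaker inhibition), compound 1 gives 1500 nM.
Compound 2, `Cc1cccc(C(=O)C#Cc2cn(COCCO)c(=O)[nH]c2=O)c1` — in this assay compound 2 gives 700 nM.

For the measured compounds named here, compound 2 holds the lowest of the two numbers; the single measured step, a 2.1-fold lower number from compound 1 to compound 2 (0.33 log units; beyond the scatter), lies beyond the scatter and places compound 1 at the higher number. Compound 3, `Cc1ccccc1C(=O)C#Cc1cn(COCCO)c(=O)[nH]c1=O`, has not yet been measured. Its change from compound 2 is 2-methylphenyl in place of 3-methylphenyl on a carbonyl carbon. Going by the values given here, no measured step moves a methyl group alone from one place on the aromatic ring to another; the only step, a 2.1-fold lower number from compound 1 to compound 2 (0.33 log units; beyond the scatter), swaps both the group and its place, so it bears on this change only loosely and gives no clear direction. In this assay no step beyond the scatter is therefore expected, with perhaps a slight drift toward a higher number. Compound 3 is expected to give about 900 nM, with a range from 350 nM to 2500 nM. The step this estimate means is expected to be a 1.3-fold higher number from compound 2 to compound 3 (0.11 log units; within the scatter).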

Compound 3, half-maximal inhibitory concentration: 2200 nM
The estimate for compound 3 lay 2.4-fold (0.39 log units) below the measured number; the range from low to high includes it.
By their numbers in this assay, from the lowest: compound 2; then compounds 1 and 3 (each within the scatter of the next).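

Here the two compounds have the same atoms joined differently, so the methyl's place on the ring can be read alone: 2-methylphenyl in place of 3-methylphenyl on a carbonyl carbon gives a 3.1-fold higher number from compound 2 to compound 3 (0.50 log units; beyond the scatter) in this assay. Where the methyl sits therefore matters in this series, and the change is large enough to cancel the earlier gain from the swap to 3-methylphenyl. 2-methylphenyl in place of 4-methoxyphenyl gives a 1.5-fold higher number from compound 1 to compound 3 (0.17 log units; within the scatter), so these two compounds cannot be told apart, and nothing measured here accounts for the effect of moving the methyl.

On these data alone, it remains open whether a different group on the ring, such as an amine or a carboxylic acid, would respond to its place in the same way. The three compounds also share one core, so they say nothing about how changes there would alter these numbers.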